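A few compounds are considered here, and "the series" means these few. Any claim that something is new, unique, unknown or untested is made for them only; others in the source may bear on it.

Compound 1, `C#CCSc1nnc(CCC)n1N1C(=O)c2ccccc2C1=O`, and compound 2, `C#CCSc1nnc(-c2cc(OC)c(OC)c(OC)c2)n1N1C(=O)c2ccccc2C1=O`, share the same core and have both been tested in a functional assay on HepG2 cells (Homo sapiens) for cytotoxicity, read by MTT assay, with a stated time of 48 h; a higher number here means a weaker inhibitor, a lower number a stronger inhibitor. In this assay compound 1 gives only a limit, > 200000 nM. In this assay compound 2 likewise gives only a limit, > 200000 nM. Among the measured compounds shown here, compound 2 thus stands at the limit of > 200000 nM in this assay, at which 2 of the 2 values shown sit; no real number exists for it, and no step between measured compounds can be read off. Compound 3, `COc1cc(-c2nnc(SCC(=O)c3ccccc3C)n2N2C(=O)c3ccccc3C2=O)cc(OC)c1OC`, has not yet been measured. It differs from compound 2 by (2-methylphenyl)carbonyl in place of ethynyl on a saturated chain carbon bound to a sulfur. With both measured values sitting at a limit, there is no basis for expecting a change beyond the scatter in either direction, and the expected step is an at least 1.3-fold lower number from compound 2 to compound 3 (0.12 log units; that floor lies within the scatter). Compound 3 is therefore estimated at about 150000 nM in this assay, within a range from 50000 nM to 400000 nM, with a fair chance that only a limit is reported again.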

Compound 3, half-maximal inhibitory concentration: > 200000 nM
Compound 3: no number, only a limit; the forecaster's own chance of this, stated with the estimate: 60%; at least 1.3-fold (0.12 log units) between middle value and limit.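

Among the compounds shown here, compound 3, like compound 2, gives only a limit in this assay, so no step between compound 2 and compound 3 can be read. The compounds shown leave open what real value any of them has and whether changing a group shifts it, as all sit at one limit: the limit of > 200000 nM in this assay, at which 3 of the 3 values shown sit.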